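The compounds below may be only part of what the source reports. "The series", "measured", "known", "first", "only" and "open" are said of these compounds alone.

Compound 2, `CCCc1nc2ccccc2c(=O)n1/N=C1/C(=O)Nc2ccccc21`, gives 3.23 in a physicochemical assay for lipophilicity, in phosphate buffer, measured as octanol-water partition (on this read-out higher numbers stand for higher lipophilicity and lower numbers for lower lipophilicity), the highest of the two numbers at hand; compound 1, `Cc1nc2ccccc2c(=O)n1/N=C1/C(=O)Nc2ccccc21`, gives 2.23 in this assay. Among the compounds with values here, the single measured step, a number 1.00 log units higher from compound 1 to compound 2 (beyond the scatter), came with ethyl in place of hydrogen on a saturated chain carbon bound to an aromatic carbon. Compound 3, `O=C1Nc2ccccc2/C1=N\n1c(-c2ccccc2)nc2ccccc2c1=O`, differs from compound 2 by phenyl in place of propyl on an aromatic carbon; in words, phenyl in place of propyl on an aromatic carbon. Within the data shown here, both changes add carbon only, but here the entering group is an aromatic ring rather than a chain, and no measured pair shows such a swap. On that basis a rise smaller than the earlier step is expected for compound 3, namely a number 0.37 log units higher from compound 2 to compound 3 (beyond the scatter). Compound 3 is therefore estimated at 3.6 in this assay, with a range from 3.1 to 4.1.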

Compound 3, partition coefficient: 4.03
Estimate against measurement, compound 3: 0.43 log units below, and the stated range covers the measured number.
By their numbers in this assay, from the lowest: compound 1; then compound 2; then compound 3.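

In this assay, the aromatic carbon between two ring nitrogen atoms now carries a ring instead of a chain, and the number rises again: the swap gives a number 0.80 log units higher from compound 2 to compound 3 (beyond the scatter) on the propyl compound, while the same place read against the methyl compound gives a number 1.80 log units higher from compound 1 to compound 3 (beyond the scatter) in all. Methyl, propyl and phenyl at this one place thus fall into a single order, and phenyl, which brings one six-membered aromatic ring of carbon only, stands beyond the scatter from both chains. Nothing at hand accounts for the size of these steps.

The compounds shown leave open whether a longer chain at this place would reach or pass phenyl. They also leave open where a pyridine ring, an amine or a carboxylic acid would fall in this order.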